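This account rests on a few compounds, and the source may have more. Where it says the series, first, only, none or still open, it means among the compounds named here.

For the measured compounds named here, compound 2 `O=C(Nc1cccc([N+](=O)[O-])c1)C(Cl)Cl` is the one compound with a number in a functional assay on BGC-823 cells (Homo sapiens) for antiproliferative activity, read by MTT assay, with a stated time of 72 h (on this read-out lower numbers stand for stronger inhibition and higher numbers for weaker inhibition), where compound 2 gives 123000 nM. Compound 1 `O=C(Nc1cccc(F)c1)C(Cl)Cl`, which shares its core, is reported in this assay as "not determined" (no result reported). Compound 3 `O=C(Nc1cccc(OC(F)(F)F)c1)C(Cl)Cl` has not been measured; it differs from compound 2 by trifluoromethoxy in place of nitro on an aromatic carbon. Going by the values given here, with no measured step available, the change is expected to leave the result within the scatter, in no clear direction. Compound 3 is therefore estimated at 100000 nM, with a range from 30000 nM to 300000 nM, a step of a 1.2-fold lower number from compound 2 to compound 3 (0.09 log units; within the scatter).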

Compound 3, half-maximal inhibitory concentration: 142000 nM
Estimate against measurement, compound 3: 1.4-fold (0.15 log units) below; the measured number falls inside the stated range.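

Trifluoromethoxy in place of nitro on this aromatic carbon gives a 1.2-fold higher number from compound 2 to compound 3 (0.06 log units; within the scatter) in this assay. For the compounds shown here, for the first time there is a measured step at this position, and it shows that this exchange of one group for the other leaves the read-out within the scatter. No measured property of either group is available to bear on this result. Still open, on these data alone, is whether an amine or a carboxylic acid on the same aromatic carbon would carry the number beyond the scatter. Equally open, as far as these compounds go, is whether a change elsewhere on the shared core would do so.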